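Methoxy for Methyl: Expected Solubility of Compound 3

The compounds below may be only part of what the source reports. "The series", "measured", "known", "first", "only" and "open" are said of these compounds alone.

Of the compounds shown here, two sharing one core have been measured so far. Compound 1 `Cc1cc2cn[nH]c2cc1-c1cccc2c(N)c(C(N)=O)cnc12` gives 10.5 ug/mL in a physicochemical assay for solubility, read by HPLC, in phosphate buffer, measured as kinetic solubility, with a stated time of 24 h, at pH 7.4; a higher number here means a more soluble compound, a lower number a less soluble compound. Among the compounds with values here, compound 2 `Cc1cc2cn[nH]c2cc1-c1ccc(F)c2c(N)c(C(N)=O)cnc12` gives 5.2 ug/mL in this assay, which is the lowest of the two numbers; the only other number is that of compound 1, higher by a 2.0-fold lower number from compound 1 to compound 2 (0.31 log units; beyond the scatter), a change introduced by fluoro in place of hydrogen on an aromatic carbon.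

Compound 3 `COc1cc2cn[nH]c2cc1-c1ccc(F)c2c(N)c(C(N)=O)cnc12` is not yet measured. It differs from compound 2 in one place: methoxy in place of methyl on an aromatic carbon. Within the data shown here, the single measured step, from compound 1 to compound 2, concerns a different position and a different pair of groups, so no measured step bears directly on this change. With nothing comparable among the measured pairs, the step from compound 2 to compound 3 is expected to stay within the usual scatter of this assay, in either direction, as a 1.3-fold higher number from compound 2 to compound 3 (0.10 log units; within the scatter). On that basis compound 3 is estimated to give 6.5 ug/mL, with a range from 2.5 ug/mL to 17 ug/mL in this assay.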

Compound 3, solubility: 7.3 ug/mL
Compound 3: the middle estimate sits 1.1-fold (0.05 log units) below what was measured; the measured number falls inside the stated range.
By their numbers in this assay, from the lowest: compounds 2, 3 and 1 (each within the scatter of the next, the first and the last beyond it).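

Within the data shown here, the exchange of methyl for methoxy on an aromatic carbon, ortho to a large group, gives in this assay a 1.4-fold higher number from compound 2 to compound 3 (0.15 log units; within the scatter) and so provides the first reading at this position, as the only earlier step, a 2.0-fold lower number from compound 1 to compound 2 (0.31 log units; beyond the scatter), concerned a different place on the shared core. At this position, the move from a methyl with 1 heavy atom and 0 hydrogen-bond acceptors to a methoxy with 2 heavy atoms and 1 hydrogen-bond acceptor leaves compound 2 and compound 3 within the scatter of each other, so this one pair shows no separable difference between the two groups in this read-out. No available measurement bears on why the two compounds read as they do.

What the compounds shown leave open is whether this result extends to other groups at the same place, such as an ethoxy, an amine or a carboxylic acid, any of which might give a step beyond the scatter. They also leave open whether the same exchange would read alike on the core of compound 1, which carries hydrogen where compound 2 and compound 3 carry fluoro.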